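Halogen swap on the pendant phenyl ring; solubility notes

The compounds below may be only part of what the source reports. "The series", "measured", "known", "first", "only" and "open" are said of these compounds alone.

Compound 1 `CCc1ccc(-c2nc3c(c(C)nn3-c3ccccc3)c(-c3ccccc3Cl)c2C#N)cc1` and compound 2 `CCc1ccc(-c2nc3c(c(C)nn3-c3ccccc3)c(-c3ccccc3F)c2C#N)cc1` share one core; compound 3 `Cc1nn(-c2ccccc2)c2nc(-c3ccc(F)cc3)c(C#N)c(-c3ccccc3O)c12` and the unmeasured compound 4 `Cc1nn(-c2ccccc2)c2nc(-c3ccc(Cl)cc3)c(C#N)c(-c3ccccc3O)c12` share another. The difference between the two cores is not broken down here.

In a physicochemical assay for solubility, read by spectrophotometry, in phosphate buffer, with a stated time of 18 h, at pH 7.4 (a lower number here means a less soluble compound, a higher number a more soluble compound), compound 1 gives 1700 nM, and compound 2 gives 1700 nM. Compound 3 gives 6000 nM in this assay, the highest of the three numbers, beyond the scatter from both others.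

Within the first core, the change chloro in place of fluoro on an aromatic carbon produced no change at the digits printed from compound 2 to compound 1 (within the scatter). The change to compound 4 is chloro in place of fluoro on an aromatic carbon. The two are the same kind of change, not the same: the first sits ortho to a large group, the second para to a large group.

Compound 4 is expected to give 5000 nM in this assay, with a range from 2400 nM to 10000 nM. This rests on the measured pair, where the move from compound 2 to compound 1 gave no change at the digits printed from compound 2 to compound 1 (within the scatter); the expected step from compound 3 to compound 4 is therefore a 1.2-fold lower number from compound 3 to compound 4 (0.08 log units; within the scatter), with the range widened slightly because the place of the change is not the same and the core differs. Whether the second core answers to the same swap as the first is not known from two measured pairs alone.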

Compound 4, solubility: 3800 nM
Beside the measured number, compound 4's estimate is 1.3-fold (0.12 log units) above it; the range from low to high includes it.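

Working notes on carrying the swap across cores: in this assay, chloro in place of fluoro gives a 1.6-fold lower number from compound 3 to compound 4 (0.20 log units; within the scatter) as the 4-fluorophenyl to 4-chlorophenyl change, and the same kind of change in the core of compound 1 gives no change at the digits printed from compound 2 to compound 1 (within the scatter) in the other pair, so neither step can be told from repeat measurement. For these two pairs alone, the swap carries from one core to the other without a step beyond the scatter, although its place differs; this does not show that the two steps are equal, that a third core would answer in the same way, or whether core and place each matter, as both differ at once between the pairs. Nothing at hand bears on why the swap behaves this way in either core.

From the compounds shown here alone, what the two cores contribute on their own stays open, as the pairs compare only within a core and the cores differ in more than one place. Going by these compounds, the pairs also exchange one halogen for another only, so it remains open how an amine, a carboxylic acid or a longer chain at the same place on the ring would read in this assay in either core.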